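A few compounds are considered here, and "the series" means these few. Any claim that something is new, unique, unknown or untested is made for them only; others in the source may bear on it.

Measured so far:
- compound 1, `CCCNC(=C\C(=O)/C=C/c1ccc(O)c(OC)c1)/C=C/c1ccc(O)c(OC)c1`: 0.1%
- compound 2, `COc1cc(/C=C/C(=O)CC(=O)/C=C/c2ccc(OC(C)=O)c(OC)c2)ccc1OC(C)=O`: 0%
- compound 3, `CC(=O)Oc1ccc(/C=C/C(=O)/C=C(/C=C/c2ccc(OC(C)=O)cc2)NCC(C)C)cc1`: 0%

The read-out throughout is a functional assay for inhibition, read by spectrophotometry, with a stated time of 30 min, tested at 1 uM; on this read-out higher numbers stand for more inhibition at the one concentration tested (going by the name of the read-out) and lower numbers for less inhibition. In this assay compound 1 gives 0.1%, compound 2 gives 0% and compound 3 gives 0%. The three numbers lie within the usual scatter of one another, so no order among them can be read; each sits at the floor of the read-out, and nothing in the set so far shows any inhibition at the concentration tested. Within the data shown here, no pair of measured compounds differs in a single place, so no step size has been established.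

The next compound, compound 4, `COc1cc(/C=C/C(=O)/C=C(/C=C/c2ccc(O)c(OC)c2)NCC(C)C)ccc1O`, is taken from compound 1 by the change (methyl in place of hydrogen on a saturated chain carbon bound to two saturated chain carbons). The same difference, cut one bond further out, reads propylamino to isobutylamino. Compound 3 already carries an isobutylamino group on a related scaffold and gives 0% in this assay, and compound 1 gives 0.1%, so nothing measured points to any inhibition at the concentration tested.

The step from compound 1 to compound 4 is therefore expected to be a number 0.4 percentage points higher from compound 1 to compound 4 (within the scatter), that is, no movement beyond the scatter in either direction. For compound 4 the estimate in this assay is 0.5%, with a range from 0% to 8%.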

Compound 4, a percentage reported as inhibition, at one concentration (the size of the read-out at that concentration, not a potency): 0.09%
Compound 4: the middle estimate sits 0.4 percentage points above what was measured, within the range that was stated.
By their numbers in this assay, from the lowest: compounds 2, 3, 4 and 1 (each within the scatter of the next).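

Among these compounds, the change from propylamino to isobutylamino, methyl in place of hydrogen on a saturated chain carbon bound to two saturated chain carbons, gives a number 0 percentage points lower from compound 1 to compound 4 (within the scatter) in this assay as the first step that can be read. With the core of compound 1 held fixed, this single change at this position brings out no inhibition at the one concentration tested, and since compound 1 and compound 4 both sit at the floor of the read-out, the step cannot show whether the added methyl has any effect of its own. No measurement shown here offers an explanation for this result.

The compounds shown leave open whether any group on this chain can lift the read-out off its floor, for example a longer chain such as octyl in place of isobutyl, or a carboxylic acid on the chain. They also leave open whether the free hydroxyl groups of compound 1 and compound 4 matter, as no pair shown differs in that place alone.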